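Propyl in Place of But-1-yn-1-yl on Compound 2

This account rests on a few compounds, and the source may have more. Where it says the series, first, only, none or still open, it means among the compounds named here.

Of the compounds shown here, two have values so far in a functional assay on KB cells (Homo sapiens), read by MTT assay; on this read-out higher numbers stand for weaker inhibition and lower numbers for stronger inhibition. Compound 1 `Nc1ccn([C@@H]2O[C@H](CO)[C@](O)(C3CC3)[C@H]2O)c(=O)n1` gives > 350000 nM, which is a limit of the assay and not a number. Going by the values given here, compound 2 `CCC#C[C@@]1(O)[C@@H](CO)O[C@@H](n2ccc(=O)[nH]c2=O)[C@@H]1O` gives 226000 nM, the only true number on hand, so it is the one anchor for what follows.

Compound 3 `CCC[C@@]1(O)[C@@H](CO)O[C@@H](n2ccc(=O)[nH]c2=O)[C@@H]1O` carries propyl in place of the but-1-yn-1-yl of compound 2 on a saturated ring carbon (propyl in place of but-1-yn-1-yl on a saturated ring carbon). Among the compounds with values here, no measured pair shows what such a swap does in this assay, so the expectation is for no step beyond the scatter, in either direction. The expected change is a 1.2-fold higher number from compound 2 to compound 3 (0.06 log units; within the scatter), an estimate that starts from compound 2 at 226000 nM. Compound 3 is expected at about 260000 nM, with an estimated range of 110000 nM to 350000 nM.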

Compound 3, half-maximal inhibitory concentration: > 350000 nM
Compound 3: no number, only a limit; the forecaster's own chance of this, stated with the estimate: 35%; at least 1.3-fold (0.12 log units) between middle value and limit.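

In this assay compound 3 gives > 350000 nM, which is a limit and not a number. Going by these compounds alone, the exchange of but-1-yn-1-yl for propyl on this saturated ring carbon is the first step read at this position, and it comes out as an at least 1.5-fold higher number from compound 2 to compound 3 (0.18 log units; that floor lies within the scatter), so among the compounds with this change the only true number stays with but-1-yn-1-yl. How far the step runs past that floor cannot be read because the comparison ends at a limit: the limit of > 350000 nM in this assay, at which 2 of the 3 values shown sit.

The swap removes the triple bond and one carbon together, so the compounds shown do not separate the two; a butyl chain on the same carbon would do so. On these data alone, whether ethynyl or a longer alkynyl chain there would give a true number also stays open.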